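The compounds below may be only part of what the source reports. "The series", "measured", "known", "first", "only" and "open" are said of these compounds alone.

In an assay on isolated protein for inhibition of eIF-2-alpha kinase GCN2 (Homo sapiens) (a higher number here means a weaker inhibitor, a lower number a stronger inhibitor), the three measured compounds gave these numbers:
compound 1 `CCn1cc(Nc2ncc3cnn(-c4ccc(OC)cc4)c3n2)cn1`: 133 nM;
compound 2 `CCn1cc(Nc2ncc3c(C)nn(-c4ccc5ncccc5c4)c3n2)cn1`: 23 nM;
compound 3 `Cc1nn(-c2ccc3ncccc3c2)c2nc(Nc3cnn(C4CCNCC4)c3)ncc12`: 11 nM.

Compound 3 gives the lowest number of the three. Among the measured compounds shown here, the only measured single change, a 2.1-fold lower number from compound 2 to compound 3 (0.32 log units; beyond the scatter), is modest but beyond the scatter, and compound 1 sits much higher still. Compound 4 `Brc1nn(-c2ccc3ncccc3c2)c2nc(Nc3cnn(C4CCNCC4)c3)ncc12` differs from compound 3 in one place: bromo in place of methyl on an aromatic carbon. No measured step touches this position, so nothing among these compounds shows how such a swap moves the number. The expectation is therefore a step of no more than the scatter, no change at the digits printed from compound 3 to compound 4 (within the scatter), in either direction. Compound 4 is estimated at 11 nM in this assay, with a range from 4 nM to 30 nM.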

Compound 4, half-maximal inhibitory concentration: 3 nM
Beside the measured number, compound 4's estimate is 3.7-fold (0.56 log units) above it; the whole stated range lies above it.
By their numbers in this assay, from the lowest: compound 4; then compound 3; then compound 2; then compound 1.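

Putting bromo in place of methyl on this aromatic carbon gives a 3.7-fold lower number from compound 3 to compound 4 (0.56 log units; beyond the scatter) in this assay. The position, on the five-membered aromatic ring, therefore responds to the swap of a single heavy atom, and the step is modest. Nothing measured here says why the number falls. Going by these compounds, whether chloro, an amine or a longer chain at this carbon would lower the number further stays open. On these data alone, this step also comes from one pair carrying piperidin-4-yl, so whether bromo would act alike with the ethyl of compound 2 remains unknown.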